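Dropping an amino group: from compound 2 to compound 3

This account rests on a few compounds, and the source may have more. Where it says the series, first, only, none or still open, it means among the compounds named here.

All numbers here come from a functional assay on A549 cells (Homo sapiens), read by MTT assay, with a stated time of 72 h; a lower number here means a stronger inhibitor, a higher number a weaker inhibitor. Compound 1, `C#Cc1cn([C@@H]2O[C@H](CO)[C@@H](O)[C@H]2O)c2ncnc(OC)c12`, gives 8160 nM. Compound 2, `COc1nc(N)nc2c1c(-c1ccco1)cn2[C@@H]1O[C@H](CO)[C@@H](O)[C@H]1O`, returns only a limit of the assay, > 20000 nM, so no exact number is known for it. Among the two values shown, compound 2 therefore stands at the limit of > 20000 nM in this assay, at which 1 of the 2 values shown sits, the weak end. Compound 3, `COc1ncnc2c1c(-c1ccco1)cn2[C@@H]1O[C@H](CO)[C@@H](O)[C@H]1O`, has not been measured. It differs from compound 2 in one place: hydrogen in place of amino on an aromatic carbon. Among the measured compounds shown here, no pair of measured compounds shows this same change on its own, so the size of the step is open. Compound 1 also carries hydrogen in place of amino on that aromatic carbon, but it differs from compound 2 in a second place as well, so its value only shows that a compound without the amino group can give a number inside the range of this assay. The step of an at least 1.6-fold lower number from compound 2 to compound 3 (0.22 log units; that floor lies within the scatter) is expected to move toward stronger inhibition, but by an uncertain amount. Compound 3 is estimated at 12000 nM, likely between 3000 nM and 40000 nM.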

Compound 3, half-maximal inhibitory concentration: 30 nM
The estimate for compound 3 lay 400-fold (2.60 log units) above the measured number, outside the stated range (below it).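

With the furan-2-yl group in place, hydrogen in place of amino on the aromatic carbon between two ring nitrogen atoms gives an at least 660-fold lower number from compound 2 to compound 3 (2.82 log units; beyond the scatter), so a single change at this position can move the number very far. The value of compound 2 is a limit and not an exact number: the limit of > 20000 nM in this assay, at which 1 of the 3 values shown sits. With hydrogen on that carbon, furan-2-yl in place of ethynyl on an aromatic carbon gives a 270-fold lower number from compound 1 to compound 3 (2.43 log units; beyond the scatter), so the missing amino group alone does not produce the low number of compound 3; the furan-2-yl group matters as well.

From the compounds shown here alone, it remains open whether a methyl group or a chlorine atom on that carbon would keep the number low, or whether only hydrogen does. Going by these compounds, it also remains open how much an amino group there would change the number with ethynyl in place of furan-2-yl.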